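Replacing 3-Bromophenyl with Pyridin-3-yl in Compound 3

This account rests on a few compounds, and the source may have more. Where it says the series, first, only, none or still open, it means among the compounds named here.

Compound 1 `CCN(Cc1ccc(Br)cc1)c1cccc(C(=O)N2CCc3ccc(OS(N)(=O)=O)cc3C2)c1`: 84.5%
Compound 2 `CCN(Cc1cccc(Br)c1)c1cccc(C(=O)N2CCc3ccc(OS(N)(=O)=O)cc3C2)c1`: 24.9%

In an assay on HEK293 cells for inhibition of Steryl-sulfatase (Homo sapiens), tested at 1 uM (a lower number here means a weaker effect, a higher number a stronger effect of the compound at the concentration tested), compound 2 stands lowest of the two measured compounds; it trails compound 1 by a large margin, seen in a number 59.6 percentage points lower from compound 1 to compound 2 (beyond the scatter). Compound 3 `CCN(Cc1cccnc1)c1cccc(C(=O)N2CCc3ccc(OS(N)(=O)=O)cc3C2)c1` differs from compound 2 in one place: pyridin-3-yl in place of 3-bromophenyl on a saturated chain carbon bound to a nitrogen on an aromatic ring. Within the data shown here, the single measured step, a number 59.6 percentage points lower from compound 1 to compound 2 (beyond the scatter), concerns only a shift of bromine position on the phenyl ring and does not bear on exchanging that ring for pyridin-3-yl, so the data give no direct guidance. Compound 3 is therefore expected to stay close to compound 2, with no step beyond the scatter, as a number 0.1 percentage points higher from compound 2 to compound 3 (within the scatter). The estimate for compound 3 is 25%, ranging from 5% to 55%.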

Compound 3, a percentage reported as inhibition, at one concentration (the size of the read-out at that concentration, not a potency): 33.5%
The estimate for compound 3 lay 8.5 percentage points below the measured number, and the stated range covers the measured number.
By their numbers in this assay, from the lowest: compounds 2 and 3 (each within the scatter of the next); then compound 1.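

In this assay, pyridin-3-yl in place of 3-bromophenyl gives a number 8.6 percentage points higher from compound 2 to compound 3 (within the scatter), so these two groups are not told apart at this position. Pyridin-3-yl in place of 4-bromophenyl gives a number 51 percentage points lower from compound 1 to compound 3 (beyond the scatter), which leaves 4-bromophenyl as the only one of the three groups with a high read-out. Nothing available explains either step. The compounds shown leave open whether the high read-out needs bromine, as 4-chlorophenyl or 4-methylphenyl could show. They also leave open how pyridin-4-yl or unsubstituted phenyl would compare.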